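The source may hold more compounds than are shown below. What is called first, only, known or untested is meant among the compounds shown, and "the series" means these compounds.

Measured compounds:
Compound 1 `CCOC(=O)CCCCCOc1cccc(CN(C(=O)c2ccc(-c3cccc(-c4ccccc4)c3)cc2)C(C)C)c1` — in an ADME assay on BJ cells (Homo sapiens) for cytotoxicity, read by CellTiter-Glo and resazurin assay, with a stated time of 72 h (a lower number here means that less compound is needed, a higher number that more compound is needed for the effect), compound 1 gives > 26000 nM, which is a limit of the assay and not a number.
Compound 2 `CCOC(=O)CCCCCOc1cccc(CN(C(=O)c2ccc(-c3cccc(C(C)=O)c3)cc2)C(C)C)c1` — in this assay compound 2 gives > 26000 nM, again a limit.
Compound 3 `CCOC(=O)CCCCCOc1cccc(CN(C(=O)c2ccc(-c3cc(F)cc(OC)c3)cc2)C(C)C)c1` — in this assay compound 3 gives > 26000 nM, again a limit.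

Compound 3 therefore stands at the same limit as the two other measured compounds; no number places it above or below them. The step to compound 4 `CCOC(=O)CCCCCOc1cccc(CN(C(=O)c2ccc(-c3cc(OC)ccc3F)cc2)C(C)C)c1` is 2-fluoro-5-methoxyphenyl in place of 3-fluoro-5-methoxyphenyl on an aromatic carbon, a rearrangement that keeps the same atoms. Within the data shown here, the steps that bear on it are a step that the two limits leave unreadable from compound 1 to compound 3 and a step that the two limits leave unreadable from compound 2 to compound 3, and also a step that the two limits leave unreadable from compound 1 to compound 2; all three are unreadable because of the limit of > 26000 nM in this assay, at which 3 of the 3 values shown sit. With every neighbour sitting at the limit, no size or direction can be read for the new step, and the expectation is that compound 4 stays at the limit as well. The estimate for compound 4 in this assay is 40000 nM, between 15000 nM and 150000 nM. The step this estimate implies, a step that the limit leaves unreadable from compound 3 to compound 4, is expected to be none beyond the scatter.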

Compound 4, half-maximal effective concentration: > 26000 nM
Compound 4: no number, only a limit; the forecaster's own chance of this, stated with the estimate: 80%; the middle value lies beyond the limit too.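

In this assay compound 4 gives > 26000 nM, which is a limit and not a number. The steps from compound 1, compound 2 and compound 3 to compound 4 therefore cannot be read: the limit of > 26000 nM in this assay, at which 4 of the 4 values shown sit.

The compounds shown leave open how far any of the four lies from that limit, and whether any of these changes shifts the read-out at all.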